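The source may report more compounds than this note shows. Statements on the series, on what has been measured and on what is new or still open speak of the compounds shown alone.

Of the compounds shown here, three sharing one core have been measured in an ADME assay on Huh-7 cells (Homo sapiens) for cytotoxicity; a higher number here means that more compound is tolerated, a lower number that less compound is tolerated. Compound 1 `CN1CCN(CCNCc2cn(-c3ccc(F)cc3F)nc2-c2ccc(OC(F)(F)F)cc2)CC1` gives 18000 nM. Compound 2 `Cc1cccc(-c2nn(-c3ccc(F)cc3F)cc2CNCCN2CCN(C)CC2)c1` is reported only as a limit of the assay, > 20000 nM. Compound 3 `CN1CCN(CCNCc2cn(-c3ccc(F)cc3F)nc2-c2cccc(Cl)c2)CC1` gives 15000 nM. The change from the 4-(trifluoromethoxy)phenyl of compound 1 to the 3-methylphenyl of compound 2 gives an at least 1.1-fold higher number from compound 1 to compound 2 (0.04 log units; that floor lies within the scatter), and to the 3-chlorophenyl of compound 3 gives a 1.2-fold lower number from compound 1 to compound 3 (0.08 log units; within the scatter); exchanging methyl for chloro gives an at least 1.3-fold lower number from compound 2 to compound 3 (0.12 log units; that floor lies within the scatter). Compound 3 therefore stands together with compound 1, the two numbers separated only by a gap inside the scatter, while compound 2 sits at the limit (the limit of > 20000 nM in this assay, at which 1 of the 3 values shown sits).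

Compound 4 `CN1CCN(CCNCc2cn(-c3ccc(F)cc3F)nc2-c2ccc(N(C)C)cc2)CC1` differs from compound 3 in the same place that the three measured steps probe: 4-(dimethylamino)phenyl in place of 3-chlorophenyl on an aromatic carbon. Every measured exchange of this aryl group, whether to methyl, chloro or trifluoromethoxy substitution, has stayed within the scatter, so no step beyond the scatter in this assay is expected here either, with the main uncertainty being whether a number or only a limit is returned. The expected change a 1.1-fold higher number from compound 3 to compound 4 (0.03 log units; within the scatter) is small, and for compound 4 the estimate is 16000 nM, lying between 7000 nM and 30000 nM.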

Compound 4, half-maximal cytotoxic concentration: > 20000 nM
Compound 4: a limit, no number (the forecaster's own chance of this, stated with the estimate: 30%); at least 1.2-fold (0.09 log units) between middle value and limit.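

In this assay, the 4-(dimethylamino)phenyl group puts a nitrogen-bearing substituent at this position for the first time among the compounds shown, on the aromatic carbon next to the ring nitrogen, and compound 4 is reported only as a limit of the assay, > 20000 nM. The readable steps are an at least 1.3-fold higher number from compound 3 to compound 4 (0.12 log units; that floor lies within the scatter) and an at least 1.1-fold higher number from compound 1 to compound 4 (0.04 log units; that floor lies within the scatter); both are floors only, so the true steps could be larger, but neither establishes a change beyond the scatter. The step between compound 2 and compound 4 cannot be read, and the series now rests as much on the limit as on numbers: the limit of > 20000 nM in this assay, at which 2 of the 4 values shown sit.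

As far as these compounds go, how far compound 2 and compound 4 lie past that limit stays unknown, so no order can be given for them, and the tolerated concentrations of the aryl groups are only partly resolved. Also open, from the compounds shown here alone, is whether a carboxylic acid or a primary amine on this aryl group, or a pyridine in place of its phenyl ring, would give a step beyond the scatter.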